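The source may report more compounds than this note shows. Statements on the series, on what has been measured and on what is new or still open speak of the compounds shown alone.

Measured compounds in a functional assay on OVCAR-4 cells (Homo sapiens) for antiproliferative activity, with a stated time of 48 h; a lower number here means that less compound is tolerated, a higher number that more compound is tolerated:

- compound 1, `Cc1cc(O)c(C2=NN(c3ccc(S(N)(=O)=O)cc3)C(c3ccccc3O)C2)cc1Cl`: 51800 nM
- compound 2, `Cc1cc(O)c(C2=NN(c3ccc(S(N)(=O)=O)cc3)C(/C=C/c3ccccc3)C2)cc1Cl`: 48600 nM

Within the data shown here, compound 2 holds the lowest of the two numbers in this assay, yet its only neighbour is compound 1, and the gap between the two lies within the scatter, so no order between them can be read. Among the measured compounds shown here, the single step measured so far, a 1.1-fold lower number from compound 1 to compound 2 (0.03 log units; within the scatter), exchanges the group on the saturated ring carbon and leaves the number essentially unchanged.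

Compound 3, `COc1ccc(C2CC(c3cc(Cl)c(C)cc3O)=NN2c2ccc(S(N)(=O)=O)cc2)c(OC)c1OC`, is not yet measured. Its change from compound 2 is 2,3,4-trimethoxyphenyl in place of 2-phenylethenyl on a saturated ring carbon. The step from compound 1 to compound 2 is the only one that bears on this position, and it was within the scatter; it concerned a different pair of groups, so it speaks only indirectly for the present exchange. Nothing in the data points to a direction, and the working expectation for compound 3 is a number close to that of compound 2, with any step expected to stay within the scatter, a 1.0-fold higher number from compound 2 to compound 3 (0.01 log units; within the scatter). The estimate for compound 3 in this assay is 50000 nM, with a range from 20000 nM to 125000 nM.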

Compound 3, concentration lethal to 50% of the cells: > 100000 nM
Compound 3 ended at the assay's limit; the forecaster's own chance of this, stated with the estimate: 10%; at least 2.0-fold (0.30 log units) between middle value and limit.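

In this assay compound 3 gives > 100000 nM, which is a limit of the assay and not a number. Among these compounds, the saturated ring carbon is therefore not indifferent to exchange, as the earlier pair alone might have suggested: with 2,3,4-trimethoxyphenyl in place of 2-phenylethenyl comes the first step beyond the scatter at this position, an at least 2.0-fold higher number from compound 2 to compound 3 (0.31 log units; beyond the scatter). Against 2-hydroxyphenyl the reading is weaker, with an at least 1.9-fold higher number from compound 1 to compound 3 (0.28 log units; that floor lies within the scatter), so no order can be read for that pair, and the full size of both steps stays unknown because the reading stops at a limit: the limit of > 100000 nM in this assay, at which 1 of the 3 values shown sits.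

The compounds shown do not separate whether the shift follows the methoxy groups as a set or the exchange of 2-phenylethenyl for a directly attached aromatic ring; a phenyl group with a single methoxy group on this carbon would bear on that. As far as these compounds go, the 4-sulfamoylphenyl and 5-chloro-2-hydroxy-4-methylphenyl groups stay the same throughout, so the effect of a carboxylic acid in place of the sulfamoyl group remains open.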